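The source may report more compounds than this note shows. Statements on the series, on what has been measured and on what is new or still open speak of the compounds shown alone.

In a functional assay on HCT-116 cells (Homo sapiens) for inhibition; on this read-out higher numbers stand for weaker inhibition and lower numbers for stronger inhibition:
- compound 1 `COCCOc1cc(/C=C/c2ccc3ccccc3c2)ccc1OC`: > 5000 nM
- compound 2 `Cc1ccc(/C=C/c2ccc3ccccc3c2)cc1`: > 5000 nM
- compound 3 `Cc1ccc(/C=C\c2ccc3ccccc3c2)cc1`: > 5000 nM

Compound 3 gives > 5000 nM, which is a limit and not a number. The series offers only (the limit of > 5000 nM in this assay, at which 3 of the 3 values shown sit).

Compound 4 `CN(C)c1ccc(/C=C\c2ccc3ccccc3c2)cc1` carries dimethylamino in place of methyl on an aromatic carbon, para to a large group: dimethylamino in place of methyl on an aromatic carbon. For the measured compounds named here, the one measured step, a step that the two limits leave unreadable from compound 2 to compound 3, concerns only (the fact that compounds 2 and 3 differ only in the configuration as drawn), so it gives no size for this change. With no readable step to go on, only a loose expectation is possible in this assay, leaning towards stronger inhibition. The expected step is an at least 1.6-fold lower number from compound 3 to compound 4 (0.22 log units; that floor lies within the scatter). For compound 4 the estimate is 3000 nM, with an expected range of 300 nM to 10000 nM.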

Compound 4, half-maximal inhibitory concentration: 3660 nM
Compound 4: the middle estimate sits 1.2-fold (0.09 log units) below what was measured; measured number inside the range.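

In this assay compound 4 gives 3660 nM. Compound 1, compound 2 and compound 3 stay at a limit: the limit of > 5000 nM in this assay, at which 3 of the 4 values shown sit.

Dimethylamino in place of methyl on an aromatic carbon, para to a large group, gives an at least 1.3-fold lower number from compound 3 to compound 4 (0.13 log units; that floor lies within the scatter). On these data alone, this floor is all that can be read, so the true size of the change stays unknown.

As far as these compounds go, it remains open whether a plain amino group or a methoxy group in this place would give a lower number. From the compounds shown here alone, it is also open whether dimethylamino would behave alike with the double bond drawn E.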